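A few compounds are considered here, and "the series" means these few. Any claim that something is new, unique, unknown or untested is made for them only; others in the source may bear on it.

For the measured compounds named here, in a physicochemical assay for lipophilicity, at pH 7.4 (on this read-out higher numbers stand for higher lipophilicity and lower numbers for lower lipophilicity), compound 1 (`CC(C(=O)O)c1nn(Cc2cn3cc(OCC4CC4)c(Cl)cc3n2)c2ccccc2c1=O`) gives 2.44 and compound 2 (`C[C@@H](C(=O)O)c1nn(Cc2cn3cc(OCC4CC4)c(Cl)cc3n2)c2ccccc2c1=O`) gives 2.41, so compound 2 stands within the scatter of the only other measured compound. Going by the values given here, the single measured step, a number 0.03 log units lower from compound 1 to compound 2 (within the scatter), concerns only whether a configuration is drawn at the stereocentre (the fact that one of compounds 1 and 2 is drawn with a defined configuration and the other without, at the place where they differ). Compound 3 (`O=C(O)Cc1nn(Cc2cn3cc(OCC4CC4)c(Cl)cc3n2)c2ccccc2c1=O`) has hydrogen in place of methyl on a saturated chain carbon bound to an aromatic carbon and a carbonyl carbon, which turns 1-carboxyethyl into carboxymethyl. Among the compounds with values here, no measured step removes a group, so that small step gives little guide to size, and the expectation rests on the structural change alone, starting from compound 2 at 2.41. A modest move to lower numbers is expected in this assay, with an estimated step of a number 0.36 log units lower from compound 2 to compound 3 (beyond the scatter). For compound 3 the expected value is 2.05, within an estimated range from 1.7 to 2.4.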

Compound 3, distribution coefficient: 2.13
The estimate for compound 3 lay 0.08 log units below the measured number; the measured number falls inside the stated range.
By their numbers in this assay, from the lowest: compounds 3, 2 and 1 (each within the scatter of the next, the first and the last beyond it).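

For the compounds shown here, this is the first change in the atoms themselves at this saturated chain carbon: 1-carboxyethyl becomes carboxymethyl, whereas the earlier pair differed only in whether a configuration was drawn. In this assay, the change reads as a number 0.28 log units lower from compound 2 to compound 3 (within the scatter), and as a number 0.31 log units lower from compound 1 to compound 3 (beyond the scatter), so the same replacement of methyl by hydrogen falls on either side of the scatter depending on the partner and remains a small step at the edge of what this read-out can separate. Nothing available here accounts for the size of this step.

From the compounds shown here alone, whether an ethyl group or a longer chain on this carbon would continue the trend from hydrogen to methyl remains open. So does the reading with an amine or a hydroxyl group in the same place.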